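Aryl ring swap in the enone series: outlook for compound 4

The source may hold more compounds than are shown below. What is called first, only, known or untested is meant among the compounds shown, and "the series" means these compounds.

Compound 1 `CCOc1ccc(/C=C(/Sc2ccc(C)cc2)C(=O)c2ccc(Cl)cc2)cc1OC` gives 25000 nM in a functional assay on DU-145 cells (Homo sapiens) for inhibition, read by trypan blue exclusion, with a stated time of 96 h; a lower number here means a stronger inhibitor of growth, a higher number a weaker inhibitor of growth. Compound 2 `CCOc1ccc(/C=C(\C(=O)c2ccc(Cl)cc2)S(=O)(=O)Cc2ccc(F)cc2)cc1OC` gives 50000 nM in this assay, and compound 3 `CCOc1ccc(/C=C(\C(=O)c2ccc(Cl)cc2)S(=O)(=O)Cc2ccccc2Cl)cc1OC` gives 10000 nM there. Compound 3 therefore holds the lowest of the three numbers: the step of a 2.5-fold lower number from compound 1 to compound 3 (0.40 log units; beyond the scatter) is modest but beyond the scatter, as is a 5.0-fold lower number from compound 2 to compound 3 (0.70 log units; beyond the scatter), whereas a 2.0-fold higher number from compound 1 to compound 2 (0.30 log units; within the scatter) stays within the scatter. Every measured step varies the sulfur-bearing part of the molecule; none varies the aryl ring placed on a double-bonded chain carbon bound to a double-bonded chain carbon.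

Compound 4 `COc1cc(/C=C(\C(=O)c2ccc(Cl)cc2)S(=O)(=O)Cc2ccccc2Cl)cc(OC)c1` differs from compound 3 exactly at that ring: 3,5-dimethoxyphenyl in place of 4-ethoxy-3-methoxyphenyl on a double-bonded chain carbon bound to a double-bonded chain carbon. Among the measured compounds shown here, no measured step bears on this change, so the three numbers give no direction for it, and the expectation is a step no larger than the scatter, with the uncertainty widened accordingly. The estimate for compound 4 in this assay is 10000 nM, with a range from 3500 nM to 30000 nM. The expected step of no change at the digits printed from compound 3 to compound 4 (within the scatter) is accordingly small.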

Compound 4, concentration for 50% growth inhibition: > 100000 nM
Compound 4 ended at the assay's limit; the forecaster's own chance of this, stated with the estimate: 10%; middle value at least 10-fold (1.00 log units) from the limit.
By their numbers in this assay, from the lowest: compound 3; then compounds 1 and 2 (each within the scatter of the next). At a limit, above all of these: compound 4.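

Among the compounds shown here, the aryl ring on a double-bonded chain carbon bound to a double-bonded chain carbon, which no earlier step varied, strongly affects growth inhibition: 3,5-dimethoxyphenyl in place of 4-ethoxy-3-methoxyphenyl gives an at least 10-fold higher number from compound 3 to compound 4 (1.00 log units; beyond the scatter), a larger step than any among the sulfur-bearing variations. In this assay compound 4 gives a limit of the assay, not a number: the limit of > 100000 nM in this assay, at which 1 of the 4 values shown sits. The two groups match in hydrogen-bond donors, hydrogen-bond acceptors and net charge, so those counts do not separate them.

This single step cannot show whether the result follows from the ethoxy group leaving or from the different placement of the methoxy groups. Going by these compounds, how a ring carrying an amine or a carboxylic acid would read, and whether the ring effect carries over to the sulfanyl compound 1, remains open.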